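Aryl substituent variation on a cyclopentyl urea series

The source may report more compounds than this note shows. Statements on the series, on what has been measured and on what is new or still open speak of the compounds shown alone.

Measured compounds:
compound 1 `Cc1ccccc1C1(CNC(=O)Nc2c(C(C)C)cccc2C(C)C)CCCC1` gives 17 nM
compound 2 `Cc1cccc(C2(CNC(=O)Nc3c(C(C)C)cccc3C(C)C)CCCC2)c1` gives 15 nM
compound 3 `CC(C)c1cccc(C(C)C)c1NC(=O)NCC1(c2ccc(F)cc2)CCCC1` gives 23 nM

The three measured compounds share one core and differ only in the aromatic ring on the saturated ring carbon. In an assay on microsomes for inhibition of acyl-CoA:cholesterol acyltransferase (Oryctolagus cuniculus) (a higher number here means a weaker inhibitor, a lower number a stronger inhibitor), compound 3 has the highest number of the three, but its distance to the others is small: a 1.4-fold higher number from compound 1 to compound 3 (0.13 log units; within the scatter) and a 1.5-fold higher number from compound 2 to compound 3 (0.19 log units; within the scatter) both lie within the scatter, as does a 1.1-fold lower number from compound 1 to compound 2 (0.05 log units; within the scatter). Compound 4 `COc1cccc(C2(CNC(=O)Nc3c(C(C)C)cccc3C(C)C)CCCC2)c1` has not yet been measured in this assay. It differs from compound 3 by 3-methoxyphenyl in place of 4-fluorophenyl on a saturated ring carbon. For the measured compounds named here, the steps that bear on this change are the three exchanges of the aromatic ring among compounds 1, 2 and 3, none of which moved the number beyond the scatter. A further exchange of the same kind is therefore expected to give no step beyond the scatter, with a 1.2-fold lower number from compound 3 to compound 4 (0.06 log units; within the scatter) as the expected change. Compound 4 is estimated at 20 nM, between 8 nM and 50 nM.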

Compound 4, half-maximal inhibitory concentration: 13 nM
Compound 4: middle estimate off by 1.5-fold (0.19 log units), on the high side, within the range that was stated.
By their numbers in this assay, from the lowest: compounds 4, 2, 1 and 3 (each within the scatter of the next).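

In this assay, the place on the saturated ring carbon also accepts 3-methoxyphenyl, which brings a hydrogen-bond acceptor that 4-fluorophenyl does not have, with no step beyond the scatter (a 1.8-fold lower number from compound 3 to compound 4 (0.25 log units; within the scatter); a 1.3-fold lower number from compound 1 to compound 4 (0.12 log units; within the scatter)). Methoxy in place of methyl on an aromatic carbon, the narrowest change among these compounds, also stays within the scatter (a 1.2-fold lower number from compound 2 to compound 4 (0.06 log units; within the scatter)), so all six steps among the four compounds now lie within it. Nothing in the data shown offers an account of these small differences.

The aromatic rings shown carry only methyl, fluoro or methoxy, so it remains open whether a carboxylic acid or an amine on that ring would move the number beyond the scatter. From the compounds shown here alone, a pyridine ring in place of the phenyl ring is equally open.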